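The source may report more compounds than this note shows. Statements on the series, on what has been measured and on what is new or still open speak of the compounds shown alone.

Compound 1, `Cn1ccc2cc(-c3cnccc3/C=C/C(=O)O)ccc21`, was examined in an assay on a protein complex for inhibition of CDK8/Cyclin C (Homo sapiens), with a stated time of 1 h (a higher number here means a weaker inhibitor, a lower number a stronger inhibitor), where compound 1 gives 26.8 nM. Compound 2, `O=C(/C=C/c1ccncc1-c1ccc2ccccc2c1)NC1CC1`, carries an amide in place of the acid and gives 40.1 nM in this assay; the two values lie within the usual scatter of each other. For compound 3, `O=C(/C=C/c1ccncc1-c1ccc2cccnc2c1)N1CCOCC1`, the entry in this assay reads "not determined" (no result reported), so no number is available for it. Compound 4, `CNC(=O)/C=C/c1ccncc1-c1ccc2c(ccn2C)c1`, is compound 1 with one change: methylamino in place of hydroxy on a carbonyl carbon, so that the carboxy becomes a methylcarbamoyl. Since compound 2 with an amide gives 40.1 nM, close to compound 1, the step of a 1.1-fold higher number from compound 1 to compound 4 (0.05 log units; within the scatter) is expected to stay within the scatter, in no clear direction. Compound 4 is estimated to give 30 nM, in a range from 10 nM to 90 nM.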

Compound 4, half-maximal inhibitory concentration: 77.6 nM
Compound 4: middle estimate off by 2.6-fold (0.41 log units), on the low side; the measured number falls inside the stated range.
By their numbers in this assay, from the lowest: compounds 1, 2 and 4 (each within the scatter of the next, the first and the last beyond it).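

The change from hydroxy to methylamino on a carbonyl carbon brings a 2.9-fold higher number from compound 1 to compound 4 (0.46 log units; beyond the scatter) in this assay and is the first single change shown at this position. It shows that the assay responds modestly to this change, which the earlier comparison across differing compounds could not isolate. Nothing shown accounts for the step.

On these data alone, it remains open whether an unsubstituted amino group, a dimethylamino group or a methoxy group on the same carbonyl carbon would stay close to compound 1 or to compound 4. As far as these compounds go, whether the step carries over to another core also remains open.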